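Replacing 4-(bromomethyl)phenyl with 2-methylphenyl

The source may hold more compounds than are shown below. What is called first, only, known or untested is meant among the compounds shown, and "the series" means these compounds.

Measured in a functional assay on KBVIN cells (Homo sapiens) for antiproliferative activity, read by sulforhodamine B assay, with a stated time of 3 days; a higher number here means that more compound is needed for the effect, a lower number that less compound is needed:
Compound 1 `CCC1=C(O)c2c(oc(-c3ccc(SC)cc3)cc2=O)C(CC)(CC)C1=O`: 1.38 uM
Compound 2 `CCC1=C(O)c2c(oc(-c3ccc(CBr)cc3)cc2=O)C(CC)(CC)C1=O`: 27.9 uM

Of these two numbers, the higher belongs to compound 2, at 27.9 uM. Compound 3 `CCC1=C(O)c2c(oc(-c3ccccc3C)cc2=O)C(CC)(CC)C1=O` keeps the shared core and has 2-methylphenyl in place of 4-(bromomethyl)phenyl on an aromatic carbon. Going by the values given here, one measured step bears on this change, a 20-fold higher number from compound 1 to compound 2 (1.31 log units; beyond the scatter), where bromomethyl took the place of methylsulfanyl on an aromatic carbon. Among the compounds with values here, that step shows that a change on this aromatic ring can shift the number widely, but no measured compound carries 2-methylphenyl. Compound 3 lacks the bromomethyl group of compound 2, whose 27.9 uM is the high end so far, so a partial return towards compound 1 seems likely. The expected move is a 3.5-fold lower number from compound 2 to compound 3 (0.54 log units; beyond the scatter), smaller than the measured step. Compound 3 is estimated at 8 uM, with an expected range of 2 uM to 30 uM.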

Compound 3, concentration for half-maximal effect: 2.41 uM
Beside the measured number, compound 3's estimate is 3.3-fold (0.52 log units) above it; the range from low to high includes it.
By their numbers in this assay, from the lowest: compounds 1 and 3 (each within the scatter of the next); then compound 2.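

The change to 2-methylphenyl gives a 12-fold lower number from compound 2 to compound 3 (1.06 log units; beyond the scatter) in this assay and so shows that a group on this aromatic carbon can bring the number down from the high value seen with 4-(bromomethyl)phenyl. The second comparison, a 1.7-fold higher number from compound 1 to compound 3 (0.24 log units; within the scatter) in this assay, stays within the usual scatter, so 2-methylphenyl and 4-(methylsulfanyl)phenyl cannot be told apart here. Among these three compounds, only 4-(bromomethyl)phenyl stands apart, and nothing shown gives a reason for that.

The compounds shown leave open whether the bromine atom itself matters or the whole bromomethyl group does, which a close relative such as aminomethyl or hydroxymethyl could test. They also leave open how a carboxylic acid or a longer chain on this phenyl ring would read.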